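The source may report more compounds than this note shows. Statements on the series, on what has been measured and on what is new or still open speak of the compounds shown alone.

Compound 1 `CNC(=O)N1CCCc2ccc(NC(=O)c3cccc(-c4cc[nH]n4)c3)cc21` gives 89.7% in a functional assay on MV4-11 cells (Homo sapiens) for antiproliferative activity, with a stated time of 6 days, tested at 6.25 uM; a lower number here means a weaker effect, a higher number a stronger effect of the compound at the concentration tested. Compound 2 `CNC(=O)N1CCCc2ccc(NC(=O)c3ccc(-c4cccnc4)cc3)cc21` gives 92.1%. Compound 3 `CNC(=O)N1CCCc2ccc(NC(=O)c3ccc(-c4ccn(C(C)=O)n4)cc3)cc21` gives 91.4%.

All three numbers sit within the usual scatter of one another, so compound 1 cannot be set apart from compound 2 or compound 3 on these values. Compound 4 `CNC(=O)N1CCCc2ccc(NC(=O)c3cccc(-c4cnn(C(C)=O)c4)c3)cc21` is reached from compound 1 by one change: 1-acetyl-1H-pyrazol-4-yl in place of 1H-pyrazol-3-yl on an aromatic carbon. Going by the values given here, the only measured step of a related kind is a number 0.7 percentage points lower from compound 2 to compound 3 (within the scatter), where a 1-acetyl-1H-pyrazol-3-yl also enters in place of another aromatic ring on the same kind of carbon and the number stays within the scatter. On that single example, the step of a number 0.3 percentage points higher from compound 1 to compound 4 (within the scatter) is expected to stay within the scatter as well. For compound 4 the estimate is 90%, with a range from 80% to 97%.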

Compound 4, a percentage reported as inhibition, at one concentration (the size of the read-out at that concentration, not a potency): 82%
Compound 4: the middle estimate sits 8 percentage points above what was measured, within the range that was stated.
By their numbers in this assay, from the lowest: compounds 4, 1, 3 and 2 (each within the scatter of the next, the first and the last beyond it).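

In this assay, placing 1-acetyl-1H-pyrazol-4-yl instead of 1H-pyrazol-3-yl on this aromatic carbon, meta to a large group, gives a number 7.7 percentage points lower from compound 1 to compound 4 (within the scatter). This position therefore tolerates a group with more heavy atoms and no hydrogen-bond donor, with no effect that can be told from the scatter. Nothing measured here offers a reason for this result.

The step changes the acetyl group and the ring's attachment together, so 1H-pyrazol-4-yl alone would be needed to separate them. Going by these compounds, how an amine or a carboxylic acid would behave at this place stays open.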